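Aryl variation at the saturated ring carbon: cytotoxicity notes

The source may hold more compounds than are shown below. What is called first, only, known or untested is meant among the compounds shown, and "the series" means these compounds.

Measured compounds in a functional assay on OVCAR cells (Homo sapiens) for cytotoxicity, read by sulforhodamine B assay, with a stated time of 48 h; on this read-out lower numbers stand for stronger inhibition and higher numbers for weaker inhibition:
compound 1 `O=CCN1N=C(c2ccc3ccccc3c2)CC1c1cccc(Cl)c1Cl` gives 15100 nM
compound 2 `COc1ccc(C2CC(c3ccc4ccccc4c3)=NN2CC=O)cc1O` gives 2160 nM
compound 3 `O=CCN1N=C(c2ccc3ccccc3c2)CC1c1cccc(Br)c1` gives 10800 nM

Compound 3 stands second highest of the three numbers. Within the scatter lies a 1.4-fold lower number from compound 1 to compound 3 (0.15 log units; within the scatter); beyond it lie a 5.0-fold higher number from compound 2 to compound 3 (0.70 log units; beyond the scatter) and a 7.0-fold lower number from compound 1 to compound 2 (0.84 log units; beyond the scatter). Across the shared core, the only group that moves is the aryl group on the saturated ring carbon, and the halogenated phenyls sit together while the 3-hydroxy-4-methoxyphenyl of compound 2 sits apart at the lower number.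

Compound 4 `O=CCN1N=C(c2ccc3ccccc3c2)CC1c1ccco1` is the next member: furan-2-yl in place of 3-bromophenyl on a saturated ring carbon. All three measured steps bear on it, since each exchanges the group at this same carbon. The two halophenyl-to-halophenyl comparisons suggest that swapping one plain aromatic group for another changes little, whereas the step to the group carrying hydroxy and methoxy shows that an oxygen-bearing aryl can lower the number modestly. Within the data shown here, no measured step introduces a five-membered ring or a ring heteroatom, so the direction is uncertain. The expectation is a step of a 1.4-fold lower number from compound 3 to compound 4 (0.13 log units; within the scatter) in this assay, at most modest and leaning toward a lower number. Compound 4 is therefore estimated at 8000 nM, with a range from 2500 nM to 25000 nM.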

Compound 4, half-maximal inhibitory concentration: 18000 nM
The estimate for compound 4 lay 2.3-fold (0.35 log units) below the measured number; measured number inside the range.
By their numbers in this assay, from the lowest: compound 2; then compounds 3, 1 and 4 (each within the scatter of the next).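

In this assay, replacing a six-membered aromatic ring of carbon only with the five-membered furan-2-yl, which carries a ring oxygen, gives a 1.7-fold higher number from compound 3 to compound 4 (0.22 log units; within the scatter) and a 1.2-fold higher number from compound 1 to compound 4 (0.08 log units; within the scatter), so among these compounds neither the five-membered ring nor the ring hetero atom separates compound 4 from the two halogenated phenyl compounds. The 3-hydroxy-4-methoxyphenyl group still stands apart, with an 8.3-fold higher number from compound 2 to compound 4 (0.92 log units; beyond the scatter), which shows that the oxygen and hydrogen-bond acceptor of furan-2-yl do not by themselves reproduce the lower number of compound 2. No measurement shown here accounts for the separation of compound 2 from compounds 1, 3 and 4.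

From the compounds shown here alone, it remains open whether a 3-hydroxyphenyl or a 4-methoxyphenyl group alone on the saturated ring carbon would match compound 2, or whether both oxygen substituents are needed together. Also open, going by these compounds, is how an aminophenyl group at this carbon would compare, and whether a carboxylic acid or a longer chain in place of the formylmethyl group would preserve the separation seen between compound 2 and compound 4.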